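From carboxy to dimethylcarbamoyl on a shared core

The compounds below may be only part of what the source reports. "The series", "measured", "known", "first", "only" and "open" are said of these compounds alone.

Compound 1 `CCC(C)N(C(=O)[C@H](CC(=O)OC)NC(=O)OC(C)(C)C)C1(C(=O)NCc2ccccc2)CCN(Cc2ccccc2)CC1`: 19000 nM
Compound 2 `CC(C)(C)N(CC(=O)N(Cc1ccccc1)C1(C(=O)NCc2ccccc2)CCN(Cc2ccccc2)CC1)C(=O)O`: 21000 nM
Compound 3 `CC(C)(C)OC(=O)N[C@@H](CC(=O)O)C(=O)N(Cc1ccccc1)C1(C(=O)NCc2ccccc2)CCN(Cc2ccccc2)CC1`: > 200000 nM (a limit)

All three compounds were tested in a functional assay on CCRF-CEM cells (Homo sapiens) for inhibition, with a stated time of 72 h; a higher number here means a weaker inhibitor, a lower number a stronger inhibitor. There, compound 1 gives 19000 nM and compound 2 gives 21000 nM, two values within the usual scatter of each other. Compound 3 has no number, only a limit of > 200000 nM. For the measured compounds named here, it is the one compound of the three that sits at the limit of > 200000 nM in this assay, at which 1 of the 3 values shown sits.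

Compound 4 `CN(C)C(=O)C[C@H](NC(=O)OC(C)(C)C)C(=O)N(Cc1ccccc1)C1(C(=O)NCc2ccccc2)CCN(Cc2ccccc2)CC1` departs from compound 3 in one place: dimethylamino in place of hydroxy on a carbonyl carbon. Dimethylamino stands in place of hydroxy on a carbonyl carbon, which turns carboxy into dimethylcarbamoyl. Going by the values given here, no measured pair shows this change, so its size in this assay cannot be read directly from the data. A large step toward stronger inhibition is nevertheless expected, an at least 10-fold lower number from compound 3 to compound 4 (1.00 log units; beyond the scatter). That expectation rests on the two close relatives that do give numbers, compound 1 at 19000 nM and compound 2 at 21000 nM. The estimated value for compound 4 is 20000 nM, with an expected range from 5000 nM to 90000 nM.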

Compound 4, half-maximal inhibitory concentration: 59000 nM
Compound 4: the middle estimate sits 3.0-fold (0.47 log units) below what was measured, and the stated range covers the measured number.
By their numbers in this assay, from the lowest: compounds 1 and 2 (each within the scatter of the next); then compound 4. At a limit, above all of these: compound 3.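

In this assay, dimethylamino in place of hydroxy on a carbonyl carbon, the change that turns carboxy into dimethylcarbamoyl, gives an at least 3.3-fold lower number from compound 3 to compound 4 (0.53 log units; beyond the scatter). For the compounds shown here, this is the first reading of the change at this position, as the earlier compounds offered no measured pair: with the carboxy group replaced, compound 4 gives 59000 nM. Compound 3 has only a limit, so the step fixes the smallest size the change can have and not its full size: the limit of > 200000 nM in this assay, at which 1 of the 4 values shown sits.

The compounds shown leave open whether a smaller or larger group on the same carbonyl carbon, such as methylamino, plain amino or diethylamino, would give a lower or a higher number than dimethylamino does in compound 4. The change is also read in a single pair, so whether it would move the number in the same direction on a different substituent pattern around the shared core, or with a longer chain in place of the carboxymethyl arm, remains an open question.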